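Fluoro for Methyl on Two Related Cores

The compounds below may be only part of what the source reports. "The series", "measured", "known", "first", "only" and "open" are said of these compounds alone.

Compound 1, `Cc1ccc(-c2ccc(C)n2-c2ccc(-c3nc4ccccc4s3)cc2)cc1`: 4400 nM
Compound 2, `Cc1ccc(-c2ccc(F)cc2)n1-c1ccc(-c2nc3ccccc3s2)cc1`: 4340 nM
Compound 3, `COc1cc2nc(-c3ccc(-n4c(C)ccc4-c4ccc(C)cc4)cc3)sc2c(OC)c1OC`: 4140 nM

Of the compounds shown here, three have been measured in a functional assay on MDA-MB-231 cells (Homo sapiens) for cytotoxicity, read by sulforhodamine B assay, with a stated time of 48 h; a higher number here means a weaker inhibitor of growth, a lower number a stronger inhibitor of growth. Compound 1 gives 4400 nM and compound 2 gives 4340 nM; the two differ by one change, fluoro in place of methyl on an aromatic carbon, and the step of a 1.0-fold lower number from compound 1 to compound 2 (0.01 log units; within the scatter) shows that this swap left the result essentially unchanged. The change is fluoro in place of methyl on an aromatic carbon.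

Compound 3, with 4140 nM, carries a different core from compound 1; the difference between the two cores is not broken down here. Its value sits within the scatter of both compound 1 and compound 2, so the three measured compounds are not distinguishable on this read-out.

Compound 4 `COc1cc2nc(-c3ccc(-n4c(C)ccc4-c4ccc(F)cc4)cc3)sc2c(OC)c1OC` has not yet been measured in this assay. It stands to compound 3 exactly as compound 2 stands to compound 1: the change is fluoro in place of methyl on an aromatic carbon, made at the same kind of place on a six-membered aromatic ring of carbon only, para to a large group. Since the same change gave the step of a 1.0-fold lower number from compound 1 to compound 2 (0.01 log units; within the scatter) on the first core, the step from compound 3 to compound 4 is expected to be of similar size, namely a 1.0-fold lower number from compound 3 to compound 4 (0.00 log units; within the scatter). The estimate for compound 4 in this assay is therefore 4100 nM, with a plausible range from 2000 nM to 8500 nM, resting only on one prior pair.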

Compound 4, concentration for 50% growth inhibition: 3940 nM
Compound 4: the middle estimate sits 1.0-fold (0.02 log units) above what was measured; measured number inside the range.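

In this assay, putting 4-fluorophenyl where 4-methylphenyl stood gives a 1.1-fold lower number from compound 3 to compound 4 (0.02 log units; within the scatter), so the two compounds cannot be told apart on this read-out. Set beside the same swap on the core of compound 1, the two steps agree: the same change on two cores in this assay, a 1.0-fold lower number (0.01 log units; within the scatter) from compound 1 to compound 2 and a 1.1-fold lower number (0.02 log units; within the scatter) from compound 3 to compound 4, 1.0-fold (0.02 log units) apart, within the scatter of two such steps. This shows that, on both of these cores, trading the methyl for a fluoro leaves two compounds that this cell test does not separate; it does not show that the same would hold on any other core or in any other test, and with no step beyond the scatter, these two pairs cannot show whether a core could ever alter the size of the step.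

The compounds shown leave open what a different group in the same place would do, such as an amine, a carboxylic acid or a longer chain, and whether any of these would give a step beyond the scatter on either core. If such a step appeared, it would also become possible to ask whether it carries from one core to the other, a question that two steps within the scatter can test only weakly.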